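The source may report more compounds than this note shows. Statements on the series, on what has been measured and on what is new or still open speak of the compounds shown alone.

Working notes on the series. In an assay on isolated protein for inhibition of Myeloperoxidase (Homo sapiens) (on this read-out lower numbers stand for stronger inhibition and higher numbers for weaker inhibition), compound 3 `CCCNCCCc1c[nH]c2ccc(F)cc12` gives 340 nM, the lowest of the two numbers in hand. Compound 2 `NCCCc1c[nH]c2ccc(F)cc12` gives 650 nM, and the step of a 1.9-fold lower number from compound 2 to compound 3 (0.28 log units; within the scatter) stays within the scatter. Compound 1 `CCN(CC)Cc1c[nH]c2ccc(F)cc12` returns only a limit of the assay, > 1000 nM. The step of an at least 1.5-fold lower number from compound 1 to compound 2 (0.18 log units; that floor lies within the scatter) is read against that limit (the limit of > 1000 nM in this assay, at which 1 of the 3 values shown sits). Compound 4 `NCCCCc1c[nH]c2ccc(F)cc12` differs from compound 3 by aminomethyl in place of propylamino on a saturated chain carbon, three bonds along the chain from an aromatic carbon. From the compounds shown here alone, of the measured steps only a 1.9-fold lower number from compound 2 to compound 3 (0.28 log units; within the scatter) bears on this change, run backwards, while the lengthened chain itself is untested in this set; in this assay no step beyond the scatter is therefore expected, leaning toward a higher number. The step from compound 3 to compound 4 is expected to be a 1.8-fold higher number from compound 3 to compound 4 (0.25 log units; within the scatter). Compound 4 is accordingly estimated at 600 nM, within 250 nM to 1500 nM.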

Compound 4, half-maximal inhibitory concentration: 12 nM
The estimate for compound 4 lay 50-fold (1.70 log units) above the measured number; measured number below the stated range.
By their numbers in this assay, from the lowest: compound 4; then compounds 3 and 2 (each within the scatter of the next). At a limit, above all of these: compound 1.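

In this assay, among these compounds, the chain carrying the amine proves far more sensitive at this place than the earlier steps, both within the scatter, suggested: a 54-fold lower number from compound 2 to compound 4 (1.73 log units; beyond the scatter) is beyond the scatter, with aminomethyl in place of amino. Aminomethyl in place of propylamino is likewise a large change, a 28-fold lower number from compound 3 to compound 4 (1.45 log units; beyond the scatter). The step of an at least 83-fold lower number from compound 1 to compound 4 (1.92 log units; beyond the scatter) rests on a limit of the assay and gives only a floor: the limit of > 1000 nM in this assay, at which 1 of the 4 values shown sits.

Open, from the compounds shown here alone, is whether a longer chain ending in the same amine holds this number. Also open, going by these compounds, is how propyl on the amine nitrogen reads on the chain of compound 4.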